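The source may report more compounds than this note shows. Statements on the series, on what has been measured and on what is new or still open speak of the compounds shown alone.

Measured in a functional assay on HeLa cells (Homo sapiens) for inhibition; a higher number here means a weaker inhibitor, a lower number a stronger inhibitor:

compound 1, `Oc1ccccc1-c1cc(-c2ccc(F)cc2)cc(-c2ccccc2O)n1`, gives > 50000 nM, which is a limit of this assay.
compound 2, `Oc1cccc(-c2cc(-c3ccccc3F)cc(-c3ccccc3O)n2)c1`, gives 31100 nM.
compound 3, `Oc1cccc(-c2cc(-c3ccc(F)cc3)cc(-c3ccccc3O)n2)c1`, gives > 50000 nM, which is a limit of this assay.

Going by the values given here, compound 2 thus carries the only number in the set; the other two entries are limits. Two of the three values sit at the limit of > 50000 nM in this assay, at which 2 of the 3 values shown sit. From compound 1 to compound 3 the change is 3-hydroxyphenyl in place of 2-hydroxyphenyl on an aromatic carbon, and the step that the two limits leave unreadable from compound 1 to compound 3. From compound 2 to compound 3 the change is a 4-fluorophenyl in place of a 2-fluorophenyl on an aromatic carbon, with the step of an at least 1.6-fold higher number from compound 2 to compound 3 (0.20 log units; that floor lies within the scatter). The difference between the cores of compound 1 and compound 2 is not broken down here.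

Compound 4, `Oc1cccc(-c2cc(-c3ccccc3F)cc(-c3cccc(O)c3)n2)c1`, is not yet measured. It differs from compound 2 by 3-hydroxyphenyl in place of 2-hydroxyphenyl on an aromatic carbon. This is the same kind of change as from compound 1 to compound 3, not the same one: there the place was meta to a 2-hydroxyphenyl group and meta to a 4-fluorophenyl group, here it is meta to a 2-fluorophenyl group and meta to a 3-hydroxyphenyl group. The earlier step gives no size since both ends sit at the limit of > 50000 nM in this assay, at which 2 of the 3 values shown sit.

The step from compound 2 to compound 4 is expected to be a 1.8-fold higher number from compound 2 to compound 4 (0.25 log units; within the scatter), resting on compound 2 at 31100 nM standing close to the limit of > 50000 nM in this assay, at which 2 of the 3 values shown sit, and on the earlier change yielding no readable gain. Compound 4 is therefore estimated at 55000 nM. For compound 4 the expected range runs from 20000 nM to 150000 nM, with a fair chance that only a limit is reported.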

Compound 4, half-maximal inhibitory concentration: 16000 nM
For compound 4 the middle estimate is 3.4-fold (0.54 log units) above the measured one; the measured number lies below the stated range.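

In this assay, 3-hydroxyphenyl in place of 2-hydroxyphenyl, on the aromatic carbon next to the ring nitrogen, gives a 1.9-fold lower number from compound 2 to compound 4 (0.29 log units; within the scatter), so this one readable step does not separate compound 2 from compound 4. The same kind of replacement on the core of compound 1, leading to compound 3, cannot be read, as both ends are limits of the assay and not numbers: the limit of > 50000 nM in this assay, at which 2 of the 4 values shown sit. The series therefore offers no second size to set against the first, so the notes neither support nor contradict carrying the change from one core to another, and the result on the core of compound 2 holds only for that setting, with a 2-fluorophenyl group and a 3-hydroxyphenyl group on the shared core.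

Still open, going by these compounds, is whether a core bearing two 3-hydroxyphenyl groups would give a readable number in this assay with a 4-fluorophenyl group in place of the 2-fluorophenyl group. Also open is what an amine or a carboxylic acid in place of the hydroxyl group on these phenyl rings would do to the read-out, as every compound shown carries two hydroxyphenyl groups and one fluorophenyl group.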